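A few compounds are considered here, and "the series" means these few. Any claim that something is new, unique, unknown or untested is made for them only; others in the source may bear on it.

Compound 1 `Nc1ccccc1NC(=O)c1ccc(CSC(=S)N2CCN(c3cccnc3)CC2)cc1`: 76.9%
Compound 2 `Cc1ccc(N2CCN(C(=S)SCc3ccc(C(=O)Nc4ccccc4N)cc3)CC2)cc1`: 19.8%

In a functional assay on MGC-803 cells (Homo sapiens) for antiproliferative activity, read by CCK-8 assay, with a stated time of 72 h, tested at 8 uM (on this read-out higher numbers stand for a stronger effect at the one concentration tested and lower numbers for a weaker effect), compound 2 stands lowest of the two measured compounds, with 19.8%. Among the measured compounds shown here, the only step known is a number 57.1 percentage points lower from compound 1 to compound 2 (beyond the scatter), a large fall when the group on the ring nitrogen is exchanged. Compound 3 `CN1CCN(C(=S)SCc2ccc(C(=O)Nc3ccccc3N)cc2)CC1` carries another group at that same place: methyl in place of 4-methylphenyl on an amine nitrogen in a ring. For the measured compounds named here, no measured step exchanges an aromatic group for a methyl here, so the one known step shows only that this position matters strongly. The expected step is therefore uncertain in size: a number 15.2 percentage points higher from compound 2 to compound 3 (beyond the scatter). Compound 3 is estimated at 35%, within 10% to 65%.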

Compound 3, a percentage reported as inhibition, at one concentration (the size of the read-out at that concentration, not a potency): 84.4%
For compound 3 the middle estimate is 49.4 percentage points below the measured one, and the stated range ends below it.
By their numbers in this assay, from the lowest: compound 2; then compounds 1 and 3 (each within the scatter of the next).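

The exchange of 4-methylphenyl for methyl gives a number 64.6 percentage points higher from compound 2 to compound 3 (beyond the scatter) and shows that a ring on this nitrogen is not needed for a high reading. Methyl and pyridin-3-yl cannot be told apart, with a number 7.5 percentage points higher from compound 1 to compound 3 (within the scatter) between them, so among these three groups only 4-methylphenyl goes with a low reading. No separate measurement bears on why these groups differ.

As far as these compounds go, whether the low reading belongs to the carbon-only ring or to its methyl remains open, and unsubstituted phenyl would address that. From the compounds shown here alone, how an ethyl group or a longer chain behaves here also remains open.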